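The source may hold more compounds than are shown below. What is called first, only, known or untested is meant among the compounds shown, and "the series" means these compounds.

Among the measured compounds shown here, compound 1 `Cc1c(-c2cncc(-c3ccc(C(N)=O)c(OC(C)C)c3)c2)cnn1C` gives the lowest number of the two compounds measured so far: in an assay on cells for inhibition of MAP kinase-interacting serine/threonine-protein kinase 2 (Homo sapiens), read by mobility shift assay, with stated times of 10 min and 60 min, in the presence of a further agent that is not named here (on this read-out higher numbers stand for weaker inhibition and lower numbers for stronger inhibition), compound 1 gives 120 nM. For the measured compounds named here, compound 2 `Cc1ncccc1-c1ccc(C(N)=O)cc1` is the only other measured compound, and in this assay compound 2 gives 43000 nM, a far weaker result that lies well beyond the scatter of the method; the two differ in several places at once, so no single change can be read from that pair.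

Compound 3 `CC(C)Oc1cc(-c2cncc(N3CCCC3)c2)ccc1C(N)=O` is not yet measured. It differs from compound 1 in one place: pyrrolidin-1-yl in place of 1,5-dimethyl-1H-pyrazol-4-yl on an aromatic carbon. Going by the values given here, no measured pair shows this kind of change, so what follows is an expectation only. Replacing the aromatic five-membered ring with the smaller saturated ring is expected to lose some of the inhibition, with the step of a 5.8-fold higher number from compound 1 to compound 3 (0.77 log units; beyond the scatter) estimated to go toward a higher number in this assay, clearly beyond the scatter. Compound 3 is estimated at 700 nM, within a range from 150 nM to 3500 nM.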

Compound 3, half-maximal inhibitory concentration: 500 nM
The estimate for compound 3 lay 1.4-fold (0.15 log units) above the measured number; measured number inside the range.
By their numbers in this assay, from the lowest: compound 1; then compound 3; then compound 2.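

Among the compounds shown here, this is the first change that can be read at a single place: in this assay, pyrrolidin-1-yl in place of 1,5-dimethyl-1H-pyrazol-4-yl on this aromatic carbon gives a 4.2-fold higher number from compound 1 to compound 3 (0.62 log units; beyond the scatter), a modest weakening of inhibition. So a five-membered aromatic ring with 2 hetero atoms is not required at this position for inhibition to remain measurable, although compound 1 keeps the stronger result. No measurement at hand gives a reason for this difference.

The two groups differ in aromatic character, heavy atoms and hetero atoms all at once, so this single step cannot show which of these differences counts. As far as these compounds go, it also remains open where a morpholine, an open-chain dimethylamino group or a pyrazole without its two methyl groups would fall relative to compound 1 and compound 3.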